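Extending the alkyl chain of compound 1

A few compounds are considered here, and "the series" means these few. Any claim that something is new, unique, unknown or untested is made for them only; others in the source may bear on it.

Compound 1 `CCCCCCCCCCCCNC(=O)[C@@H](NC(=O)c1cc2ccccc2o1)[C@@H](C)O` is tested in a functional assay on SiHa cells (Homo sapiens) for cytotoxicity, read by MTT assay, with a stated time of 48 h (a lower number here means a stronger inhibitor, a higher number a weaker inhibitor), where compound 1 gives 12900 nM. Compound 2 `CCCCCCCCCCCCNC(=O)[C@@H](NC(=O)c1cc2ccccc2[nH]1)[C@@H](C)O` gives 21300 nM in this assay. Compound 3 `CCCCCCCCCCCCNC(=O)[C@@H](NC(=O)c1cc2ccccc2n1C)[C@@H](C)O` returns only a limit of the assay, > 200000 nM. Of the two numbers shown, compound 1 holds the lowest; the gap a 1.7-fold higher number from compound 1 to compound 2 (0.22 log units; within the scatter) is within the scatter, so no order between compound 1 and compound 2 is claimed. The other steps, an at least 15-fold higher number from compound 1 to compound 3 (1.19 log units; beyond the scatter) and an at least 9.3-fold higher number from compound 2 to compound 3 (0.97 log units; beyond the scatter), are beyond the scatter; both concern the aryl group and run into the limit (the limit of > 200000 nM in this assay, at which 1 of the 3 values shown sits).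

Compound 4 `CCCCCCCCCCCCCCCCCCNC(=O)[C@@H](NC(=O)c1cc2ccccc2o1)[C@@H](C)O` differs from compound 1 only by hexyl in place of hydrogen on a saturated chain carbon, ten or more bonds along the chain from an amide-type nitrogen. Among the measured compounds shown here, none of the measured steps touches the chain; each changes the aryl group or the methyl in place of hydrogen on an aromatic nitrogen, so no measured step bears directly on this change. With nothing to point to, the expectation for compound 4 is a step of no more than the scatter, a 1.2-fold higher number from compound 1 to compound 4 (0.07 log units; within the scatter). Compound 4 is therefore estimated at 15000 nM in this assay, within 5000 nM to 50000 nM.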

Compound 4, half-maximal inhibitory concentration: > 200000 nM
Compound 4: a limit, no number; the forecaster's own chance of this, stated with the estimate: 10%; at least 13-fold (1.12 log units) between middle value and limit.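

Among the compounds shown here, the chain, which no earlier step touched, is not a neutral place for change: in this assay, hexyl in place of hydrogen on a saturated chain carbon, ten or more bonds along the chain from an amide-type nitrogen, brings an at least 15-fold higher number from compound 1 to compound 4 (1.19 log units; beyond the scatter). Compound 4 gives > 200000 nM, which is a limit of the assay and not a number, so the step has a lower bound and no exact size. Changes in two different places, the methyl on the aromatic nitrogen of compound 3 and the hexyl of compound 4, now both end at the same limit: the limit of > 200000 nM in this assay, at which 2 of the 4 values shown sit.

As far as these compounds go, what a shorter chain, or a chain ending in an amine or a carboxylic acid, would give on the core of compound 1 stays open. Also open, from the compounds shown here alone, is whether hexyl has the same outcome with the 1H-indol-2-yl group of compound 2.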